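Methoxy in place of chloro on compound 1

The source may hold more compounds than are shown below. What is called first, only, known or untested is meant among the compounds shown, and "the series" means these compounds.

In a functional assay on HeLa cells (Homo sapiens) for antiproliferative activity, read by MTT assay, with a stated time of 72 h (on this read-out lower numbers stand for stronger inhibition and higher numbers for weaker inhibition), compound 1 (`O=C1COc2ccc(-c3cnc(Cl)c(NS(=O)(=O)c4ccc(F)cc4)c3)cc2N1C1CCCCC1`) gives 14300 nM as its value. Compound 2 (`COc1ccc(N2C(=O)COc3ccc(-c4cnc(Cl)c(NS(=O)(=O)c5ccc(F)cc5)c4)cc32)cc1`) gives 8320 nM there, within the scatter of compound 1. Compound 3 (`COc1ncc(-c2ccc3c(c2)N(C2CCCCC2)C(=O)CO3)cc1NS(=O)(=O)c1ccc(F)cc1`) departs from compound 1 by methoxy in place of chloro on an aromatic carbon in the form of methoxy in place of chloro on an aromatic carbon. Among the compounds with values here, the only measured step (a 1.7-fold lower number from compound 1 to compound 2 (0.24 log units; within the scatter)) exchanges cyclohexyl for 4-methoxyphenyl at another place and does not touch this carbon. No step beyond the scatter is therefore expected in this assay from this change. The expected move is a 1.6-fold lower number from compound 1 to compound 3 (0.20 log units; within the scatter) in size. For compound 3 the estimate is 9000 nM with an expected range from 2500 nM to 30000 nM as its bounds.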

Compound 3, half-maximal inhibitory concentration: 6100 nM
The estimate for compound 3 lay 1.5-fold (0.17 log units) above the measured number; the range from low to high includes it.
By their numbers in this assay, from the lowest: compounds 3, 2 and 1 (each within the scatter of the next, the first and the last beyond it).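

At this position, on an aromatic carbon next to the ring nitrogen, methoxy in place of chloro gives a 2.3-fold lower number from compound 1 to compound 3 (0.37 log units; beyond the scatter) in this assay. This is the only step in the series shown that lies beyond the scatter, so this carbon responds to substitution more clearly than the earlier cyclohexyl exchange indicated. Nothing available accounts for the step.

On these data alone, whether an amine or ethoxy on this carbon would move the number further remains open. So does whether the methoxy step holds with 4-methoxyphenyl in place of cyclohexyl.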